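The compounds below may be only part of what the source reports. "The series", "measured", "known", "first", "only" and "open" are said of these compounds alone.

Compound 1, `Cc1ccc(S(=O)(=O)N2C=CNC(=O)[C@H]2CC(=O)N[C@H](C)c2ccccc2)cc1`: in an in vitro functional assay on cells for antagonist activity at B1 bradykinin receptor (Homo sapiens), read by luminescence and calcium flux, with a stated time of 2 h (a higher number here means a weaker inhibitor, a lower number a stronger inhibitor), compound 1 gives 836 nM.
Compound 2, `Cc1ccc(S(=O)(=O)N2C=CNC(=O)[C@H]2CC(=O)N[C@H]2CCN(C)CC2(C)C)cc1`: in this assay compound 2 gives 0.42 nM.
Compound 3, `Cc1ccc(S(=O)(=O)N2C=CNC(=O)[C@H]2CC(=O)N[C@H]2CCN(CC(C)C)CC2(C)C)cc1`: in this assay compound 3 gives 0.86 nM.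

Compound 2 has the lowest number of the three, so it is the strongest inhibitor among them: compound 3 sits nearest, at a 2.0-fold higher number from compound 2 to compound 3 (0.31 log units; beyond the scatter), and compound 1 furthest, at a 2000-fold lower number from compound 1 to compound 2 (3.30 log units; beyond the scatter).

Compound 4, `Cc1cc(S(=O)(=O)N2C=CNC(=O)[C@H]2CC(=O)N[C@H]2CCN(C)CC2(C)C)c(C)cc1Cl`, is the next compound to consider. It keeps the whole of compound 2 except for one change: 4-chloro-2,5-dimethylphenyl in place of 4-methylphenyl on a sulfonyl sulfur.

Neither measured step speaks to this part of the molecule. The step from compound 1 to compound 2 and the step from compound 2 to compound 3 both alter the group on the amide nitrogen, far from the sulfonyl end, and the large and modest shifts seen there were tied to that side. The aryl group on the sulfonyl sulfur is the same in all three measured compounds, so nothing here shows how sensitive the number is to changes on it.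

With no guide, the expectation is a step of a 1.2-fold higher number from compound 2 to compound 4 (0.08 log units; within the scatter), that is, nothing beyond the scatter, and compound 4 is estimated at 0.5 nM, in a range from 0.12 nM to 2 nM.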

Compound 4, half-maximal inhibitory concentration: 0.28 nM
For compound 4 the middle estimate is 1.8-fold (0.25 log units) above the measured one; low and high end bracket the measured number.
By their numbers in this assay, from the lowest: compounds 4 and 2 (each within the scatter of the next); then compound 3; then compound 1.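

Placing 4-chloro-2,5-dimethylphenyl in place of 4-methylphenyl on the sulfonyl sulfur gives, in this assay, a 1.5-fold lower number from compound 2 to compound 4 (0.18 log units; within the scatter), so compound 2 and compound 4 cannot be told apart by this measurement. Among the compounds shown here, this is the first look at the sulfonyl end of the molecule, since the earlier steps all changed the group on the amide nitrogen, and it shows that the number need not move when this aryl ring carries a chlorine and a second methyl group, even though the group that enters is the larger of the two. Nothing available here explains why the number holds steady across this change.

Only the combined group is shown, so it remains open whether a ring with the chlorine alone, or with the two methyl groups alone, would read the same way as compound 4. From the compounds shown here alone, it is also open how far this tolerance extends to quite different groups on the sulfonyl sulfur, such as a pyridine ring, or a phenyl ring carrying an amine or a carboxylic acid.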